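A few compounds are considered here, and "the series" means these few. Any claim that something is new, unique, unknown or untested is made for them only; others in the source may bear on it.

Compound 2 `c1ccc(Cc2ccc3c(NCCCNCc4ccco4)ccnc3c2)cc1` gives the lower of the two numbers in a physicochemical assay for solubility, with a stated time of 18 h, at pH 7.4 (on this read-out higher numbers stand for higher solubility and lower numbers for lower solubility), at 4200 nM, while compound 1 `FC(F)(F)c1ccc(-c2ccc3c(NCCCNCc4ccco4)ccnc3c2)cc1` gives 32000 nM in this assay. Among the compounds with values here, the only measured step at this position, a 7.6-fold lower number from compound 1 to compound 2 (0.88 log units; beyond the scatter), shows that exchanging the group there moves the read-out well beyond the scatter. Compound 3 `COc1ccc(Oc2ccc3c(NCCCNCc4ccco4)ccnc3c2)cc1` differs from compound 2 by 4-methoxyphenoxy in place of benzyl on an aromatic carbon. Because a 7.6-fold lower number from compound 1 to compound 2 (0.88 log units; beyond the scatter) came from a change at the same place, a shift beyond the scatter is expected here too, most likely upward. Compound 3 is therefore estimated at 10000 nM, between 3000 nM and 40000 nM, a step of a 2.4-fold higher number from compound 2 to compound 3 (0.38 log units; beyond the scatter).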

Compound 3, solubility: 14500 nM
Beside the measured number, compound 3's estimate is 1.5-fold (0.16 log units) below it; measured number inside the range.
By their numbers in this assay, from the lowest: compound 2; then compound 3; then compound 1.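

In this assay, the exchange of benzyl for 4-methoxyphenoxy gives a 3.5-fold higher number from compound 2 to compound 3 (0.54 log units; beyond the scatter), while the exchange of 4-(trifluoromethyl)phenyl for 4-methoxyphenoxy gives a 2.2-fold lower number from compound 1 to compound 3 (0.34 log units; beyond the scatter). This position therefore now shows three separate levels, and benzyl and 4-methoxyphenoxy differ beyond the scatter even though each carries one six-membered aromatic ring of carbon only. Nothing available explains these shifts. As far as these compounds go, it remains open whether the methoxy group or the oxygen joining the ring to the core accounts for the rise from compound 2. From the compounds shown here alone, how an amine or a carboxylic acid at this position would compare also remains open.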